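Swapping the bicyclic sulfur substituent for a small imidazole

This account rests on a few compounds, and the source may have more. Where it says the series, first, only, none or still open, it means among the compounds named here.

Measured so far:
- compound 1, `Cn1c(-c2ccc(NC(=O)CSc3nc4ccccc4o3)cc2)nc(-c2ccccc2)c1-c1ccccc1`: 81.5%
- compound 2, `Cn1c(-c2ccc(NC(=O)CSc3nc4ccccc4s3)cc2)nc(-c2ccccc2)c1-c1ccccc1`: 82.7%

In a functional assay on HT-29 cells (Homo sapiens) for cytotoxicity, read by MTT assay, with a stated time of 24 h, tested at 80 ug/mL (on this read-out lower numbers stand for a weaker effect and higher numbers for a stronger effect at the one concentration tested), compound 1 gives 81.5%, the lowest of two numbers, with compound 2 a number 1.2 percentage points higher from compound 1 to compound 2 (within the scatter). Compound 3, `Cn1ccnc1SCC(=O)Nc1ccc(-c2nc(-c3ccccc3)c(-c3ccccc3)n2C)cc1`, is not yet measured. The change from compound 1 is 1-methyl-1H-imidazol-2-yl in place of 1,3-benzoxazol-2-yl on a sulfur. Among the measured compounds shown here, the one measured step, a number 1.2 percentage points higher from compound 1 to compound 2 (within the scatter), exchanged one bicyclic group for another and stayed within the scatter; no measured step removes the six-membered ring. For compound 3 the expected step is a number 7.5 percentage points lower from compound 1 to compound 3 (within the scatter), a modest drop that may still fall within the scatter. Compound 3 is estimated at 74%, between 50% and 88%.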

Compound 3, a percentage reported as activity, at one concentration (the size of the read-out at that concentration, not a potency): 69.4%
Beside the measured number, compound 3's estimate is 4.6 percentage points above it, within the range that was stated.
By their numbers in this assay, from the lowest: compound 3; then compounds 1 and 2 (each within the scatter of the next).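

In this assay the group on the sulfur does matter: 1-methyl-1H-imidazol-2-yl, with one ring where the earlier groups have two, gives a number 12.1 percentage points lower from compound 1 to compound 3 (beyond the scatter) and a number 13.3 percentage points lower from compound 2 to compound 3 (beyond the scatter) whereas exchanging one bicyclic group for the other stayed within the scatter. This single change removes the six-membered ring and adds a methyl group, so the two cannot be told apart here. Nothing measured here accounts for the drop. As far as these compounds go, whether a 1H-imidazol-2-yl without the methyl, or a phenyl on the sulfur, would sit with compound 3 or with the bicyclic compounds remains open.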